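The source may report more compounds than this note shows. Statements on the series, on what has been measured and on what is new or still open speak of the compounds shown alone.

Compound 1 `[N-]=[N+]=NCCCN1CCCC(COC(=O)c2ccccc2-c2ccccc2)C1`: 1820 nM
Compound 2 `O=C(NCc1ccccc1)c1ccccc1-c1ccccc1`: 7600 nM
Compound 3 `COc1ccc(OCCCCCN2CCCC(COC(=O)c3ccccc3N3C(=O)CC(C)C3=O)C2)cc1OC`: 2000000 nM

All three were tested in an in vitro functional assay on HEK ts201 cells for antagonist activity at Neuronal acetylcholine receptor; alpha3/beta4 (Homo sapiens), read by fluorescence and calcium flux; a lower number here means a stronger inhibitor, a higher number a weaker inhibitor. Among these three numbers, compound 2 stands second highest. Its nearest neighbour is compound 1, whose number is lower by more than the usual scatter of repeated measurements, so compound 1 is the stronger inhibitor of the two. Its furthest neighbour is compound 3, whose number is far higher, again well beyond the scatter.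

Compound 4 `O=C(Nc1ccccn1)c1ccccc1-c1ccccc1` differs from compound 2 in one place: pyridin-2-yl in place of benzyl on an amide-type nitrogen. Going by the values given here, no pair of measured compounds differs in just this way, so there is no measured step to lean on. The change removes a flexible one-carbon link and swaps a plain aromatic ring for one carrying a hydrogen-bond acceptor; with nothing measured to anchor it, a modest loss is the cautious expectation, though no change beyond the scatter is also plausible. Compound 4 is therefore expected to give 15000 nM in this assay, within a range from 4000 nM to 60000 nM. For compound 4 this amounts to an expected step of a 2.0-fold higher number from compound 2 to compound 4 (0.30 log units; within the scatter), toward a weaker inhibitor.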

Compound 4, half-maximal inhibitory concentration: 17500 nM
Estimate against measurement, compound 4: 1.2-fold (0.07 log units) below, within the range that was stated.
By their numbers in this assay, from the lowest: compound 1; then compound 2; then compound 4; then compound 3.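

In this assay, putting pyridin-2-yl in place of benzyl on this amide-type nitrogen gives a 2.3-fold higher number from compound 2 to compound 4 (0.36 log units; beyond the scatter), so this position now has a measured step: a modest loss of inhibition, but one beyond the scatter. This single pair cannot separate the two things that change together, since the entering group both has fewer heavy atoms and brings a nitrogen into the ring. No measurement shown here accounts for the step.

From the compounds shown here alone, it remains open whether a plain phenyl on the same nitrogen would give a number nearer to compound 2 or to compound 4, which would help separate those two changes. Also open, going by these compounds, is how pyridin-3-yl, pyridin-4-yl or a longer chain such as 2-phenylethyl would behave at this position.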